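The source may report more compounds than this note shows. Statements on the series, on what has been measured and on what is new or still open speak of the compounds shown alone.

Measured compounds:
- compound 1 `O=C(CCSc1ncc(-c2ccccc2)o1)N1CCCC1`: 177 mL/min/g
- compound 2 `O=C(CCSc1nc2ccccc2o1)N1CCCC1`: 161 mL/min/g
- compound 3 `CS(=O)(=O)C1CCN(C(=O)CCSc2nc3cc(Cl)ccc3o2)CC1`: 2.6 mL/min/g

All three numbers come from an ADME assay on microsomes from liver (Mus musculus) for metabolic stability, read by LC-MS, using NADPH, with a stated time of 45 min, tested at 0.5 uM; on this read-out higher numbers stand for fast clearance and lower numbers for slow clearance. Compound 2 sits second highest of the three. Its nearest neighbour is compound 1, whose number is within the usual scatter of that of compound 2, so no order between the two can be read. Going by the values given here, compound 3 lies far lower, well beyond the scatter, but it differs from compound 2 in more than one place, and no single step toward it is available.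

The next compound in the series is compound 4 `COc1ccc2oc(SCCC(=O)N3CCCC3)nc2c1`. Relative to compound 2 the change is methoxy in place of hydrogen on an aromatic carbon.

Among the compounds with values here, no measured pair in this set differs by only such a change, so there is no directly comparable step to lean on. What is known is that compound 1 and compound 2, which differ in their aromatic part, give numbers within the scatter of each other in this assay. On that basis the step expected from compound 2 to compound 4 is small, with no clear direction, and the step of a 1.1-fold higher number from compound 2 to compound 4 (0.02 log units; within the scatter) is estimated to stay within the scatter.

Compound 4 is therefore expected near 170 mL/min/g, with a range from 85 mL/min/g to 330 mL/min/g.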

Compound 4, intrinsic clearance in a liver preparation (reported as CLH), per the amount of preparation that the assay uses: 198 mL/min/g
Compound 4: middle estimate off by 1.2-fold (0.07 log units), on the low side; low and high end bracket the measured number.
By their numbers in this assay, from the lowest: compound 3; then compounds 2, 1 and 4 (each within the scatter of the next).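

In this assay, going by these compounds alone, the replacement of hydrogen by methoxy gives the first single-place step, a 1.2-fold higher number from compound 2 to compound 4 (0.09 log units; within the scatter), so the two compounds cannot be told apart on this read-out. At this aromatic carbon, meta to a fused ring and para to a fused ring, a group of two heavy atoms with one hydrogen-bond acceptor therefore gives a clearance number that cannot be separated from that of hydrogen, and the series stays at the fast-clearance end of the assay for this one change. No measurement is available here that would account for this result.

On these data alone, one methoxy at one carbon says little about the position as a whole: whether an amine or a carboxylic acid on the same carbon, or a longer chain such as ethoxy, would give a step beyond the scatter remains open. Also open, as far as these compounds go, is whether methoxy would read the same way on another carbon of this six-membered ring, or with a different amide part on the other end of the shared chain.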